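A few compounds are considered here, and "the series" means these few. Any claim that something is new, unique, unknown or untested is made for them only; others in the source may bear on it.

Compound 3 `COc1cc(NC(C)CCCNC(=O)OC(C)(C)C)c2nc(C(F)(F)F)cc(C)c2c1-c1ccc(C(F)(F)F)cc1` gives 0.5 h in an ADME assay on microsomes (Homo sapiens) for metabolic stability, read by LC-MS; on this read-out higher numbers stand for a longer-lived compound and lower numbers for a shorter-lived compound. Of the two plain numbers shown it stands with compound 2 `COc1cc(NC(C)CCCNC(=O)OC(C)(C)C)c2nc(C(F)(F)F)cc(C)c2c1-c1cccc(C(F)(F)F)c1`, which gives 0.3 h, and the step of a 1.7-fold higher number from compound 2 to compound 3 (0.22 log units; within the scatter) does not separate them. Compound 1 `COc1cc(NC(C)CCCN)c2nc(C(F)(F)F)cc(C)c2c1-c1cccc(C)c1` reaches only a limit of this assay, > 1 h, which is the limit of > 1 h in this assay, at which 1 of the 3 values shown sits, so no number is known for it.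

Compound 4 `COc1cc(NC(C)CCCNC(=O)OC(C)(C)C)c2nc(C(F)(F)F)cc(C)c2c1-c1cccc(C)c1` is not yet measured. It differs from compound 3 by 3-methylphenyl in place of 4-(trifluoromethyl)phenyl on an aromatic carbon. For the measured compounds named here, the only measured step in this assay, from compound 2 to compound 3, moved a trifluoromethyl group around the same phenyl ring and stayed within the scatter; it does not speak to the exchange of a trifluoromethyl for a methyl. Compound 1 carries the same 3-methylphenyl as compound 4 but differs from it in a second place as well, so its limit value is a hint only. On this footing compound 4 is expected to sit near 0.7 h in this assay, and the step of a 1.4-fold higher number from compound 3 to compound 4 (0.15 log units; within the scatter) is expected to be small, with a fair chance that the assay returns a limit rather than a number.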

Compound 4, half-life: 0.217 h
Estimate against measurement, compound 4: 3.2-fold (0.51 log units) above; the whole stated range lies above it.
By their numbers in this assay, from the lowest: compounds 4, 2 and 3 (each within the scatter of the next, the first and the last beyond it). At a limit, above all of these: compound 1.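

In this assay, the aryl group on the shared core now gives a step beyond the scatter, a 2.3-fold lower number from compound 3 to compound 4 (0.36 log units; beyond the scatter), while methyl in place of trifluoromethyl on an aromatic carbon gives only a 1.4-fold lower number from compound 2 to compound 4 (0.14 log units; within the scatter), so that exchange alone does not separate the two compounds. The tert-butoxycarbonyl group on the amine nitrogen can now be read as a change in one place, and it also gives a step beyond the scatter: an at least 4.6-fold lower number from compound 1 to compound 4 (0.66 log units; beyond the scatter). From the compounds shown here alone, compound 1 stands at a limit and not at a number, so the full size of that step stays unknown: the limit of > 1 h in this assay, at which 1 of the 4 values shown sits.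

The compounds shown leave open whether a free amine on the chain would give a similar step alongside 3-(trifluoromethyl)phenyl or 4-(trifluoromethyl)phenyl, and whether an acetyl group or a methyl group on that nitrogen would behave like hydrogen or like tert-butoxycarbonyl. They also leave open how a 4-methylphenyl, a chlorophenyl or a pyridine ring would read on the same aromatic carbon of the core.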